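Methylsulfonyl replaced on two cores: cytotoxicity notes

A few compounds are considered here, and "the series" means these few. Any claim that something is new, unique, unknown or untested is made for them only; others in the source may bear on it.

Compound 2 `CS(=O)(=O)c1ccc(-c2nc3ccc(Cl)cc3nc2-c2ccc(Cl)cc2)cc1` gives 2000 nM in an ADME assay on HepG2 cells (Homo sapiens) for cytotoxicity, read by CellTiter-Glo, with a stated time of 48 h; a higher number here means that more compound is tolerated, a lower number that less compound is tolerated. Compound 1 `C[S+]([O-])c1ccc(-c2nc3ccc(Cl)cc3nc2-c2ccc(Cl)cc2)cc1` carries the change a group of 3 heavy atoms (1 carbon, 1 oxygen, 1 sulfur; no ring) in place of a group of 4 heavy atoms (1 carbon, 2 oxygen, 1 sulfur; no ring), on an aromatic carbon and in this assay compound 1 gives 1580 nM, so the step is a 1.3-fold lower number from compound 2 to compound 1 (0.10 log units; within the scatter).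

Compound 3 `CS(=O)(=O)c1nc2ccc(Cl)cc2nc1NC1CCCCC1` has a different core; how it differs from the core of compound 2 is not broken down here. In this assay compound 3 gives 5010 nM, the highest of the three numbers, and its distance from compound 2 and from compound 1 lies beyond the scatter in both cases.

Compound 4 `C[S+]([O-])c1nc2ccc(Cl)cc2nc1NC1CCCCC1` is made from compound 3 by the change (a group of 3 heavy atoms (1 carbon, 1 oxygen, 1 sulfur; no ring) in place of a group of 4 heavy atoms (1 carbon, 2 oxygen, 1 sulfur; no ring), on an aromatic carbon). Within the data shown here, this is the same kind of change as the one from compound 2 to compound 1, but the place differs: there it was on a six-membered aromatic ring of carbon only, para to a large group; here it is on a six-membered aromatic ring with 2 nitrogen, part of a fused system of two rings, next to the ring nitrogen and ortho to a cyclohexylamino group.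

For compound 4 the expected step is a 1.3-fold lower number from compound 3 to compound 4 (0.10 log units; within the scatter), resting on the earlier step of a 1.3-fold lower number from compound 2 to compound 1 (0.10 log units; within the scatter), which stayed within the scatter. Compound 4 is thus estimated at 4000 nM, between 2000 nM and 8000 nM.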

Compound 4, half-maximal cytotoxic concentration: 15900 nM
Compound 4: the middle estimate sits 4.0-fold (0.60 log units) below what was measured; the whole stated range lies below it.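

In this assay, replacing methylsulfonyl on the second core gives a 3.2-fold higher number from compound 3 to compound 4 (0.50 log units; beyond the scatter), and this step does not match the one on the first core: the same change on two cores in this assay, a 1.3-fold lower number (0.10 log units; within the scatter) from compound 2 to compound 1 and a 3.2-fold higher number (0.50 log units; beyond the scatter) from compound 3 to compound 4, 4.0-fold (0.60 log units) apart, beyond the scatter of two such steps

For these two pairs, then, the step seen on one core did not predict the step on the other, so a result for this replacement cannot simply be carried across the series. The pairs do not show which structural difference separates the two outcomes, and two pairs give no general rule for any further core.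

Open, on these data alone, is whether the larger step depends on the cyclohexylamino group, which could be tested by setting a shorter alkylamino chain or a morpholine at that place on the core of compound 3 and repeating the replacement. Also open, as far as these compounds go, is how other groups in place of methylsulfonyl, such as a nitrile or a carboxylic acid, would behave on each of the two cores.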